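The source may report more compounds than this note shows. Statements on the series, on what has been measured and on what is new or still open speak of the compounds shown alone.

Of the compounds shown here, three from one series have been measured in a physicochemical assay for lipophilicity, read by HPLC, at pH 7.4; a higher number here means a more lipophilic compound, a lower number a more polar compound. Compound 1 `CNCc1cn(S(=O)(=O)c2cccc(OC)n2)c(-c2cccnc2F)c1F` gives 1.03, the highest of the three numbers. Compound 2 `CNCc1cn(S(=O)(=O)c2ncccc2C)c(-c2cccnc2F)c1F` gives 0.32, and compound 3 `CNCc1cn(S(=O)(=O)c2ccc(F)cn2)c(-c2cccnc2F)c1F` gives 0.42. Two steps lowered the number: a number 0.71 log units lower from compound 1 to compound 2 (beyond the scatter) and a number 0.61 log units lower from compound 1 to compound 3 (beyond the scatter), whereas a number 0.10 log units higher from compound 2 to compound 3 (within the scatter). Compound 4 `CNCc1cn(S(=O)(=O)c2cnccc2C)c(-c2cccnc2F)c1F` has not yet been measured; it differs from compound 1 by 4-methylpyridin-3-yl in place of 6-methoxypyridin-2-yl on a sulfonyl sulfur. The two measured steps that replaced the 6-methoxypyridin-2-yl group with another pyridyl group both brought a modest fall, so a modest fall of similar size is expected for compound 4, a number 0.68 log units lower from compound 1 to compound 4 (beyond the scatter). Compound 4 is therefore estimated at 0.35, within a range from -0.15 to 0.85.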

Compound 4, distribution coefficient: 0.43
Compound 4: middle estimate off by 0.08 log units, on the low side; the range from low to high includes it.
By their numbers in this assay, from the lowest: compounds 2, 3 and 4 (each within the scatter of the next); then compound 1.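

In this assay, compound 4 is the only one shown with a pyridin-3-yl group on the sulfonyl sulfur, yet the fall seen with the pyridin-2-yl groups remains (a number 0.60 log units lower from compound 1 to compound 4 (beyond the scatter)). Compound 4 cannot be told apart from the other two replacements (a number 0.01 log units higher from compound 3 to compound 4 (within the scatter); a number 0.11 log units higher from compound 2 to compound 4 (within the scatter)), so among these compounds only the 6-methoxypyridin-2-yl group stands apart. No measurement shown here explains this result. Still open, going by these compounds, is how a phenyl ring or a carboxylic acid would read at this position, and whether the methoxy group accounts for the gap.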